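Swapping the hydroxylated bicyclic amide for cyclopropyl

The source may report more compounds than this note shows. Statements on the series, on what has been measured and on what is new or still open speak of the compounds shown alone.

Compound 3 `CNC(=O)c1cc(C(=O)N[C@H]2[C@@H]3C[C@@H](O)C[C@@H]32)n([C@@H](C)c2ccccc2)n1` gives 61 nm/s in an ADME assay for permeability (a higher number here means that the compound crosses the layer faster, a lower number that the compound crosses the layer more slowly), the lowest of the three numbers at hand; compound 1 `CNC(=O)c1cc(C(=O)N[C@H]2CC[C@H](O)CC2)c([C@@H](C)c2ccc(Cl)cc2)o1` gives 150 nm/s and compound 2 `CNC(=O)c1cc(C(=O)N[C@H]2[C@@H]3C[C@@H](O)C[C@@H]32)n([C@@H](C)c2cccc(Cl)c2)n1` gives 197 nm/s. For the measured compounds named here, the only measured step, a 3.2-fold lower number from compound 2 to compound 3 (0.51 log units; beyond the scatter), involves the aromatic ring and not the amide nitrogen, so it does not bear on the change to compound 4 `CNC(=O)c1cc(C(=O)NC2CC2)n([C@@H](C)c2ccccc2)n1`, which is a group of 3 heavy atoms (3 carbon; one three-membered non-aromatic ring of carbon only) in place of a group of 7 heavy atoms (6 carbon, 1 oxygen; one three-membered non-aromatic ring of carbon only, one five-membered non-aromatic ring of carbon only), on an amide-type nitrogen. Going by the values given here, no measured step here covers a change at this position, so the expectation rests on the structures alone. Compound 4 is expected to show a higher number than compound 3, with the step estimated as a 4.1-fold higher number from compound 3 to compound 4 (0.61 log units; beyond the scatter). Compound 4 is therefore estimated at 250 nm/s, within a range of 100 nm/s to 600 nm/s.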

Compound 4, apparent permeability: > 400 nm/s
Compound 4: only a limit was reported; the forecaster's own chance of this, stated with the estimate: 0%; at least 1.6-fold (0.20 log units) between middle value and limit.
By their numbers in this assay, from the lowest: compound 3; then compounds 1 and 2 (each within the scatter of the next). At a limit, above all of these: compound 4.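

For the compounds shown here, this is the first measured change on the amide-type nitrogen: with cyclopropyl, carrying no hydrogen-bond donor or acceptor, in place of the hydroxylated bicyclic group, this assay shows an at least 6.5-fold higher number from compound 3 to compound 4 (0.81 log units; beyond the scatter). The position therefore responds at least as strongly as the aromatic carbon that carries the chloro in compound 2. The number for compound 4 is only a limit, so the step has a floor but no upper end: the limit of > 400 nm/s in this assay, at which 1 of the 4 values shown sits.

The compounds shown leave open whether the hydroxyl or the ring system accounts for the step. The same bicyclic group without its hydroxyl, or a cyclobutyl or hydroxycyclopropyl on this nitrogen, would separate the two.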